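The compounds below may be only part of what the source reports. "The series", "measured", "known", "first", "only" and "open" are said of these compounds alone.

Three close analogues share one core and differ only in the aryl group on the amine nitrogen. Compound 1 `Cc1ccc(NC2=CC(=O)c3c(nc4n3[C@H]3OC[C@@H](O)[C@H]3OC4)C2=O)cc1C` gives 1050 nM in a functional assay on MGC-803 cells (Homo sapiens) for inhibition, read by sulforhodamine B assay (on this read-out higher numbers stand for weaker inhibition and lower numbers for stronger inhibition), compound 2 `COc1ccccc1NC1=CC(=O)c2c(nc3n2[C@H]2OC[C@@H](O)[C@H]2OC3)C1=O` gives 1670 nM in this assay, and compound 3 `O=C1C(Nc2ccccc2F)=CC(=O)c2c1nc1n2[C@H]2OC[C@@H](O)[C@H]2OC1` gives 2000 nM. Compound 3 carries the largest of the three numbers, yet none of the gaps is beyond the scatter: a 1.2-fold higher number from compound 2 to compound 3 (0.08 log units; within the scatter), a 1.9-fold higher number from compound 1 to compound 3 (0.28 log units; within the scatter), and a 1.6-fold higher number from compound 1 to compound 2 (0.20 log units; within the scatter). Taken together, the three aryl groups seen so far cannot be told apart in this assay.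

Compound 4 `O=C1C(Nc2cccc(F)c2)=CC(=O)c2c1nc1n2[C@H]2OC[C@@H](O)[C@H]2OC1` is the next step from compound 3: 3-fluorophenyl in place of 2-fluorophenyl on an amine nitrogen. Among the compounds with values here, no measured pair moves a fluorine along the ring, so the measured steps bear on this change only indirectly, by showing that swapping 3,4-dimethylphenyl, 2-methoxyphenyl and 2-fluorophenyl for one another left every number within the scatter. On that basis the account expects no step beyond the scatter for compound 4 in this assay, with a 1.1-fold lower number from compound 3 to compound 4 (0.05 log units; within the scatter) as the expected change. Compound 4 is therefore estimated at 1800 nM in this assay, with a likely range from 800 nM to 4000 nM.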

Compound 4, half-maximal inhibitory concentration: 1470 nM
The estimate for compound 4 lay 1.2-fold (0.09 log units) above the measured number, within the range that was stated.
By their numbers in this assay, from the lowest: compounds 1, 4, 2 and 3 (each within the scatter of the next).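

Within the data shown here, compound 3 and compound 4 are the only pair here that keeps the same substituent and changes only its place on the aryl ring, from 2-fluorophenyl to 3-fluorophenyl, and this assay shows a 1.4-fold lower number from compound 3 to compound 4 (0.13 log units; within the scatter) for that change, so the place of the fluorine makes no difference that can be read in this assay. The two comparisons with the other aryl groups, a 1.1-fold lower number from compound 2 to compound 4 (0.06 log units; within the scatter) and a 1.4-fold higher number from compound 1 to compound 4 (0.15 log units; within the scatter) also stay within the scatter, which means that compound 1, compound 2, compound 3 and compound 4 cannot be told apart, whichever substituent the aryl ring on the amine nitrogen carries and wherever it sits among these examples. No measurement at hand gives a reason for this flat result or ties it to any property of these groups.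

From the compounds shown here alone, all four compounds carry a substituted phenyl on the amine nitrogen, so it remains open whether a different kind of group there, such as a carboxylic acid, a basic aminoalkyl chain or a longer alkyl chain, would shift the number beyond the scatter. The compounds shown also leave open what the hydroxyl group of the shared core contributes, since it is present unchanged throughout.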